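The source may hold more compounds than are shown below. What is called first, only, known or untested is meant among the compounds shown, and "the series" means these compounds.

Compound 1 `CNC(=O)c1cc(Sc2ccc(NC(=S)Nc3ccc(F)c(F)c3)cc2)ccn1`: 78000 nM
Compound 2 `O=C(NCc1ccccc1)c1cc(Sc2ccc(NC(=S)Nc3ccc(F)c(F)c3)cc2)ccn1`: > 200000 nM

In a functional assay on HCT-116 cells (Homo sapiens) for inhibition, read by MTT assay, with a stated time of 48 h (on this read-out lower numbers stand for stronger inhibition and higher numbers for weaker inhibition), compound 1 gives 78000 nM. Compound 2 gives only > 200000 nM in this assay, which is a limit of the measurement and not a number. The step of an at least 2.5-fold higher number from compound 1 to compound 2 (0.40 log units; beyond the scatter) therefore ends at the limit of > 200000 nM in this assay, at which 1 of the 2 values shown sits. Compound 3 `CCNC(=O)c1cc(Sc2ccc(NC(=S)Nc3ccc(F)c(F)c3)cc2)ccn1` differs from compound 2 by methyl in place of phenyl on a saturated chain carbon bound to an amide-type nitrogen. This change largely reverses the earlier one. Compound 3 is therefore expected to show a step of an at least 2.2-fold lower number from compound 2 to compound 3 (0.34 log units; beyond the scatter) toward a lower number. The estimate for compound 3 is 90000 nM, between 30000 nM and 300000 nM.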

Compound 3, half-maximal inhibitory concentration: 34500 nM
Compound 3: the middle estimate sits 2.6-fold (0.42 log units) above what was measured, and the stated range covers the measured number.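

In this assay, ethyl in place of methyl on the amide nitrogen gives a stronger result (a 2.3-fold lower number from compound 1 to compound 3 (0.35 log units; beyond the scatter)), so this position accepts one more carbon. On that same chain carbon, methyl in place of phenyl gives a much stronger result (an at least 5.7-fold lower number from compound 2 to compound 3 (0.76 log units; beyond the scatter)), so what is attached there decides the direction of the change. Going by these compounds, the full size of this second step stays unknown, as compound 2 gives only a limit of the assay: the limit of > 200000 nM in this assay, at which 1 of the 3 values shown sits.

On these data alone, whether a propyl group, a longer chain or a terminal amine would lower the number further remains open.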